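A few compounds are considered here, and "the series" means these few. Any claim that something is new, unique, unknown or untested is made for them only; others in the source may bear on it.

Three compounds have been measured in a functional assay on CHO cells for agonist activity at Free fatty acid receptor 1 (Homo sapiens), read by FLIPR, tested at 100 nM; a higher number here means a stronger effect of the compound at the concentration tested, a lower number a weaker effect:

Compound 1 `Cc1ccccc1OCC(=O)Nc1ccc(OCC(=O)O)c(F)c1` gives 20.8%.
Compound 2 `Cc1cccc(OCC(=O)Nc2ccc(OCC(=O)O)c(F)c2)c1` gives 45.4%.
Compound 3 `Cc1ccc(OCC(=O)Nc2ccc(OCC(=O)O)c(F)c2)cc1` gives 31.2%.

Compound 3 holds the second highest of these three numbers: a number 10.4 percentage points higher from compound 1 to compound 3 (beyond the scatter), while a number 14.2 percentage points lower from compound 2 to compound 3 (beyond the scatter). The next compound, compound 4 `CC(C)(C)c1ccc(OCC(=O)Nc2ccc(OCC(=O)O)c(F)c2)cc1`, differs from compound 3 by tert-butyl in place of methyl on an aromatic carbon, at a position para to a large group. The measured steps, a number 24.6 percentage points higher from compound 1 to compound 2 (beyond the scatter), a number 10.4 percentage points higher from compound 1 to compound 3 (beyond the scatter) and a number 14.2 percentage points lower from compound 2 to compound 3 (beyond the scatter), all concern where the methyl sits on its ring, not how large the group is; none of them bears directly on this change. The reader is therefore left with little guidance, and the expectation is a step of no more than a number 3.8 percentage points higher from compound 3 to compound 4 (within the scatter) in this assay. Compound 4 is estimated at 35%, with a range from 12% to 62%.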

Compound 4, a percentage reported as activity, at one concentration (the size of the read-out at that concentration, not a potency): 7.65%
Beside the measured number, compound 4's estimate is 27.4 percentage points above it, and the stated range ends above it.
By their numbers in this assay, from the lowest: compound 4; then compound 1; then compound 3; then compound 2.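

In this assay, within the data shown here, the earlier steps only moved a methyl around its ring, so this is the first sign that the size of the group matters: tert-butyl in place of methyl, para to a large group, gives a number 23.6 percentage points lower from compound 3 to compound 4 (beyond the scatter) and is beyond the scatter. At this position, going from one heavy atom to four therefore lowers the number rather than leaving it unchanged. No measurement shown accounts for this fall.

The compounds shown leave open how ethyl, isopropyl or methoxy would read at this place. They also leave open whether tert-butyl would lower the number in the same way on the ring position held by the methyl of compound 2.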